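Exchanging the carbamoyl group of compound 2

This account rests on a few compounds, and the source may have more. Where it says the series, first, only, none or still open, it means among the compounds named here.

Of the compounds shown here, three with a shared core have been measured in an ADME assay on MT4 cells (Homo sapiens) for cytotoxicity, read by MTT assay; a higher number here means that more compound is tolerated, a lower number that less compound is tolerated. Compound 1 `Cc1nc(NC(=O)NC2CCCCC2)c(C)c(C(OC(C)(C)C)C(=O)O)c1-c1ccc2c(c1)NCCO2` gives 30000 nM, compound 3 `Cc1nc(NC(=O)NC2CCCCC2)c(C)c(C(OC(C)(C)C)C(=O)O)c1-c1ccc(Cl)cc1` gives 16000 nM, and compound 2 `Cc1ccc(-c2c(C)nc(NC(=O)NC3CCCC3)c(C)c2C(OC(C)(C)C)C(=O)O)cc1C` gives 8000 nM. The gap between compound 2 and compound 1 lies beyond the scatter, whereas compound 3 is within the scatter of compound 2, so no order between those two can be read from the numbers. For the measured compounds named here, the only measured step with a single change, a 1.9-fold lower number from compound 1 to compound 3 (0.27 log units; within the scatter), alters the aryl group and stays within the scatter.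

Compound 4 `Cc1ccc(-c2c(C)nc(C(=O)NCc3ccccc3)c(C)c2C(OC(C)(C)C)C(=O)O)cc1C` is not yet measured. It differs from compound 2 by benzylcarbamoyl in place of (cyclopentylcarbamoyl)amino on an aromatic carbon. No measured step touches this position: the one step shown concerns a different part of the molecule, and the group that leaves here is common to all three measured compounds. There is thus nothing in the data that points to a change in either direction, and the expectation for the step of no change at the digits printed from compound 2 to compound 4 (within the scatter) is that it stays within the scatter. On that basis compound 4 is estimated to give 8000 nM in this assay, with a range from 3000 nM to 25000 nM to allow for an untested change.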

Compound 4, half-maximal cytotoxic concentration: 54000 nM
Estimate against measurement, compound 4: 6.8-fold (0.83 log units) below; the measured number lies above the stated range.
By their numbers in this assay, from the lowest: compounds 2, 3, 1 and 4 (each within the scatter of the next, the first and the last beyond it).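

For the compounds shown here, the exchange shows that this position, which carried the same kind of group in all the earlier compounds apart from ring size, can move the number in this assay: benzylcarbamoyl in place of (cyclopentylcarbamoyl)amino gives a 6.8-fold higher number from compound 2 to compound 4 (0.83 log units; beyond the scatter) and so, unlike the aryl change in a 1.9-fold lower number from compound 1 to compound 3 (0.27 log units; within the scatter), takes the number past the scatter. Going by these compounds alone, the single step changes several things together, as the group that leaves holds a five-membered non-aromatic ring of carbon only and 2 hydrogen-bond donors, while the group that enters holds a six-membered aromatic ring of carbon only and 1 hydrogen-bond donor, so the rise cannot be assigned to any one of these differences. Nothing shown here gives a measured reason for the rise.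

The compounds shown leave open whether the rise goes with the benzyl group or with the carbamoyl joined directly to the aromatic carbon, which a (benzylcarbamoyl)amino group or a cyclopentylcarbamoyl group at this position would separate. As far as these compounds go, it also remains open whether the same exchange raises the number when the 3,4-dimethylphenyl group is replaced by the aryl group of compound 3, and how a plain amine or a carboxylic acid at this position would read.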